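Methoxy to Nitro on the Methoxyphenyl Group

The source may report more compounds than this note shows. Statements on the series, on what has been measured and on what is new or still open speak of the compounds shown alone.

Compound 2 `COc1ccc(-c2nnc(N3CCN(C(=O)CN4CCN(c5ccc(OC)cc5)CC4)CC3)nc2-c2ccc(OC)cc2)cc1` and compound 1 `COc1ccc(-c2nnc(N3CCN(C(=O)CN4CCN(c5ccccc5OC)CC4)CC3)nc2-c2ccc(OC)cc2)cc1` share one core and differ only in the methoxyphenyl group on an amine nitrogen in a ring. In a functional assay on MCF7 cells (Homo sapiens) for cytotoxicity, read by MTT assay, with a stated time of 24 h (on this read-out lower numbers stand for stronger inhibition and higher numbers for weaker inhibition), compound 1 reaches only a limit of the assay, > 821000 nM. In this assay compound 2 likewise reaches only a limit, > 821000 nM. The step that the two limits leave unreadable from compound 1 to compound 2 therefore cannot be read, because both values sit at the same limit (the limit of > 821000 nM in this assay, at which 2 of the 2 values shown sit). Compound 3 `COc1ccc(-c2nnc(N3CCN(C(=O)CN4CCN(c5ccc([N+](=O)[O-])cc5)CC4)CC3)nc2-c2ccc(OC)cc2)cc1` has not yet been measured in this assay. It differs from compound 2 by nitro in place of methoxy on an aromatic carbon. Among the compounds with values here, the only measured step, from compound 1 to compound 2, touches the same methoxyphenyl group but gives no readable size, so there is no evidence that a change on this group moves the number, and none that it does not. Compound 3 is therefore expected to sit at the same limit, with the estimated step of a number no higher from compound 2 to compound 3 (the limit leaves the size open) amounting to nothing readable. The estimate for compound 3 is 821000 nM, within 400000 nM to 2000000 nM.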

Compound 3, half-maximal inhibitory concentration: > 801000 nM
Compound 3: only a limit was reported; the forecaster's own chance of this, stated with the estimate: 80%; the middle value does not contradict the limit.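

In this assay compound 3 gives > 801000 nM, which is a limit of the assay and not a number. Within the data shown here, compound 1, compound 2 and compound 3 all stop at limits, so no step among them can be read. These compounds leave open whether any change on this aromatic group shifts the cytotoxicity at all.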